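The compounds below may be only part of what the source reports. "The series", "measured", "known", "first", "only" and "open" are said of these compounds alone.

Compound 1 `COc1cc(OC)c2c(=O)c(OCC(=O)N/N=C/c3ccccc3F)c(-c3cc(OC)c(OC)c(OC)c3)oc2c1`: 2780 nM
Compound 2 `COc1cc(OC)c2c(=O)c(OCCCCN3CCCC3)c(-c3cc(OC)c(OC)c(OC)c3)oc2c1`: 18600 nM
Compound 3 `COc1cc(OC)c2c(=O)c(OCC(=O)N/N=C/c3ccco3)c(-c3cc(OC)c(OC)c(OC)c3)oc2c1`: 6050 nM

In a functional assay on MGC-803 cells (Homo sapiens) for cytotoxicity, read by MTT assay, with a stated time of 38 h (on this read-out higher numbers stand for weaker inhibition and lower numbers for stronger inhibition), compound 2 stands highest of the three measured compounds. Its nearest neighbour is compound 3, as shown by a 3.1-fold lower number from compound 2 to compound 3 (0.49 log units; beyond the scatter); compound 1 lies furthest away, as shown by a 6.7-fold higher number from compound 1 to compound 2 (0.83 log units; beyond the scatter). Compound 4 `CCN(CC)CCCOc1c(-c2cc(OC)c(OC)c(OC)c2)oc2cc(OC)cc(OC)c2c1=O` has not yet been measured. It differs from compound 2 by diethylamino in place of (pyrrolidin-1-yl)methyl on a saturated chain carbon, three bonds along the chain from an oxygen on an aromatic ring. Within the data shown here, none of the measured steps touches this kind of change: a 6.7-fold higher number from compound 1 to compound 2 (0.83 log units; beyond the scatter) and a 3.1-fold lower number from compound 2 to compound 3 (0.49 log units; beyond the scatter) replace the whole amine-bearing chain with a hydrazone-bearing one, and a 2.2-fold higher number from compound 1 to compound 3 (0.34 log units; beyond the scatter) swaps groups on the hydrazone carbon. On this evidence no step beyond the scatter is expected, a 1.0-fold lower number from compound 2 to compound 4 (0.01 log units; within the scatter). The estimate for compound 4 in this assay is 18000 nM, with a range from 7000 nM to 45000 nM.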

Compound 4, half-maximal inhibitory concentration: 40200 nM
The estimate for compound 4 lay 2.2-fold (0.35 log units) below the measured number, and the stated range covers the measured number.
By their numbers in this assay, from the lowest: compound 1; then compound 3; then compound 2; then compound 4.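

In this assay, the amine end of the chain makes a difference: diethylamino in place of (pyrrolidin-1-yl)methyl gives a 2.2-fold higher number from compound 2 to compound 4 (0.33 log units; beyond the scatter). Among these compounds, this also places the new amine further from the hydrazone compounds, with a 6.6-fold higher number from compound 3 to compound 4 (0.82 log units; beyond the scatter) and a 14-fold higher number from compound 1 to compound 4 (1.16 log units; beyond the scatter), the latter the only large step in the set. Nothing available here accounts for these steps.

The change from 4-(pyrrolidin-1-yl)butyl to 3-(diethylamino)propyl alters both the amine and the chain, and the compounds shown do not separate the two. A 3-(pyrrolidin-1-yl)propyl or 4-(diethylamino)butyl chain would bear on this, while a piperidine or morpholine on the chain remains an open question.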